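The source may report more compounds than this note shows. Statements on the series, on what has been measured and on what is new or still open speak of the compounds shown alone.

Compound 1 `O=C(NCN1CCC(c2cccc[n+]2[O-])CC1)c1ccc(F)c(Cl)c1` gives 63 nM in a functional assay on HEK293 cells for agonist activity at D(4) dopamine receptor (Homo sapiens), read by FLIPR; on this read-out lower numbers stand for an effect already at smaller amounts and higher numbers for an effect only at larger amounts of compound. Among the three measured compounds it stands second highest: compound 3 `O=C(NCN1CCC(c2cccc[n+]2[O-])CC1)c1ccc(OC(F)(F)F)c(Cl)c1` gives 170 nM, while compound 2 `Cc1cccc(NC(=O)CN2CCC(c3ccccc3C#N)CC2)c1` gives 8 nM. Compound 4 `Cc1cc(C(=O)NCN2CCC(c3cccc[n+]3[O-])CC2)ccc1Cl` differs from compound 1 by 4-chloro-3-methylphenyl in place of 3-chloro-4-fluorophenyl on a carbonyl carbon. Within the data shown here, the only measured step touching that same aryl ring, a 2.7-fold higher number from compound 1 to compound 3 (0.43 log units; beyond the scatter), was modest, and compound 2 shares no single-point step with compound 1. Because the present change is not the one measured in a 2.7-fold higher number from compound 1 to compound 3 (0.43 log units; beyond the scatter), only a small shift in this assay is expected, possibly none beyond the scatter. Compound 4 is therefore estimated at 90 nM, in a range from 30 nM to 270 nM. The expected step is a 1.4-fold higher number from compound 1 to compound 4 (0.15 log units; within the scatter).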

Compound 4, half-maximal effective concentration: 2460 nM
Compound 4: the middle estimate sits 27-fold (1.44 log units) below what was measured; the whole stated range lies below it.
By their numbers in this assay, from the lowest: compound 2; then compound 1; then compound 3; then compound 4.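

In this assay, among these compounds, the aryl group on the carbonyl carbon proves far more sensitive than the earlier compounds showed: 4-chloro-3-methylphenyl in place of 3-chloro-4-fluorophenyl gives a 39-fold higher number from compound 1 to compound 4 (1.59 log units; beyond the scatter), a larger step than the earlier one on this ring (a 2.7-fold higher number from compound 1 to compound 3 (0.43 log units; beyond the scatter)). Both groups count 8 heavy atoms, so a large step at this position needs no change in that count. No evidence is available on what lies behind this step. Still open, as far as these compounds go, is whether the methyl or the moved chloro carries the step. From the compounds shown here alone, how a methoxy or a plain phenyl would read at this position also remains unknown.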